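A few compounds are considered here, and "the series" means these few. Any claim that something is new, unique, unknown or untested is made for them only; others in the source may bear on it.

Compound 3 `COC(=O)c1cc(-c2cccc(NC(=O)c3ccc(/C=C/C(=O)c4ccc(Cl)cc4Cl)cc3)c2)on1` carries a 2,4-dichlorophenyl on a carbonyl carbon. In an ADME assay on Vero cells (Chlorocebus sabaeus) for cytotoxicity, read by MTT assay, with a stated time of 72 h (a higher number here means that more compound is tolerated, a lower number that less compound is tolerated), compound 3 gives a value that is a limit of the assay, > 40 ug/mL. Compound 1 `COC(=O)c1cc(-c2cccc(NC(=O)c3ccc(/C=C/C(=O)c4cc(F)ccc4F)cc3)c2)on1` differs only in its 2,5-difluorophenyl at that position. In this assay compound 1 likewise gives a limit, > 40 ug/mL. Compound 2 `COC(=O)c1cc(-c2cccc(NC(=O)c3ccc(/C=C/C(=O)c4ccc(Br)cc4)cc3)c2)on1` carries a 4-bromophenyl instead. In this assay compound 2 gives a limit too, > 20 ug/mL. Because of the limit of > 40 ug/mL in this assay, at which 2 of the 3 values shown sit, and (the limit of > 20 ug/mL in this assay, at which 1 of the 3 values shown sits), every one of the three values is a limit, and so the steps among them stay unreadable: a step that the two limits leave unreadable from compound 1 to compound 2, a step that the two limits leave unreadable from compound 1 to compound 3, and a step that the two limits leave unreadable from compound 2 to compound 3. Compound 3 therefore stands at the upper of the two limits, together with compound 1.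

Compound 4 `COC(=O)c1cc(-c2cccc(NC(=O)c3ccc(/C=C/C(=O)c4ccc(F)cc4F)cc3)c2)on1` is the next member of this series. The change from compound 3 is 2,4-difluorophenyl in place of 2,4-dichlorophenyl on a carbonyl carbon. The measured steps that bear on this change are the ones from compound 1 to compound 2, from compound 1 to compound 3 and from compound 2 to compound 3, all of which are unreadable; none shows any move beyond the scatter. The expected step is a number no higher from compound 3 to compound 4 (the limit leaves the size open), that is, no change beyond the scatter. Compound 4 is therefore estimated at 40 ug/mL in this assay, within a range of 20 ug/mL to 80 ug/mL.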

Compound 4, half-maximal cytotoxic concentration: > 40 ug/mL
Compound 4 was reported as a limit; the forecaster's own chance of this, stated with the estimate: 85%; the middle value lies on the limit itself.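

In this assay compound 4 gives a value that is a limit, > 40 ug/mL. Its steps to compound 1, compound 2 and compound 3 cannot be read. The compounds shown leave open where the actual half-maximal cytotoxic concentrations of these four lie, and whether the aryl group on the carbonyl carbon changes them at all.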